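A few compounds are considered here, and "the series" means these few. Any claim that something is new, unique, unknown or untested is made for them only; others in the source may bear on it.

Measured compounds:
compound 1: `C/C(=N\NC(=O)c1cccc(S(=O)(=O)N2CCOCC2)c1)c1cccc(N)c1`
compound 2: `C/C(=N\NC(=O)c1cccc(S(=O)(=O)N2CCOCC2)c1)c1ccc(F)cc1`

In a functional assay on SMMC-7721 cells (Homo sapiens) for antiproliferative activity, read by MTT assay, with a stated time of 72 h (a lower number here means a stronger inhibitor, a higher number a weaker inhibitor), compound 1 gives only a limit of the assay, > 100000 nM. Compound 2 also gives only a limit, > 100000 nM. Both values sit at the limit of > 100000 nM in this assay, at which 2 of the 2 values shown sit, so the step that the two limits leave unreadable from compound 1 to compound 2 has no readable size and no direction; the exchange of one substituted phenyl ring for another on the carbon with a double bond to nitrogen left the compound beyond the reach of this assay either way.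

Compound 3, `C/C(=N\NC(=O)c1cccc(S(=O)(=O)N2CCOCC2)c1)c1ccccc1O`, has not yet been measured. It differs from compound 2 by 2-hydroxyphenyl in place of 4-fluorophenyl on a carbon with a double bond to nitrogen. Going by the values given here, the only measured step that touches this position is the one from compound 1 to compound 2, and it is unreadable, so nothing in the data points to a gain or a loss when the 4-fluorophenyl is swapped for a 2-hydroxyphenyl. With the shared core unchanged and both measured compounds at the limit, compound 3 is expected to stay at or near the limit as well. Compound 3 is therefore estimated at 150000 nM, with a range from 30000 nM to 600000 nM. For compound 3 this estimate means a step that the limit leaves unreadable from compound 2 to compound 3, expected to be essentially none beyond the scatter.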

Compound 3, half-maximal inhibitory concentration: 1370 nM
The estimate for compound 3 lay 110-fold (2.04 log units) above the measured number, outside the stated range (below it).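

Until now this position looked silent, but the ring on the carbon with a double bond to nitrogen clearly matters in this assay: 2-hydroxyphenyl in place of 4-fluorophenyl gives an at least 72-fold lower number from compound 2 to compound 3 (1.86 log units; beyond the scatter), and 2-hydroxyphenyl in place of 3-aminophenyl gives an at least 72-fold lower number from compound 1 to compound 3 (1.86 log units; beyond the scatter). The first of these exchanges keeps the count of heavy atoms at 7 and the single six-membered aromatic ring of carbon, while the entering group brings 1 hydrogen-bond donor and 1 hydrogen-bond acceptor where the leaving group has none, so a change of this modest size is enough to bring a compound into the readable range. The step between the two earlier compounds cannot be read, and only the new compound gives a number that can anchor a comparison, as the remaining values are limits: the limit of > 100000 nM in this assay, at which 2 of the 3 values shown sit.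

Going by these compounds, how much of the gain belongs to the hydroxyl itself and how much to its place on the ring stays open, and a 2-methoxyphenyl, a 2-aminophenyl or a 4-hydroxyphenyl at this position would help to separate the two. On these data alone, the true size of both steps also stays open, as each of them starts from a limit.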